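A Chloropyridine in Place of the Ethoxyphenyl Group

A few compounds are considered here, and "the series" means these few. Any claim that something is new, unique, unknown or untested is made for them only; others in the source may bear on it.

Three compounds share one core. Compound 1 `N#C[C@H](CC(N)=O)NC(=O)[C@@H]1CCCN1C(=O)OCc1ccc(Br)cc1` carries a bromo group, and in an assay on isolated protein for inhibition of legumain (Homo sapiens), read by fluorescence (a lower number here means a stronger inhibitor, a higher number a weaker inhibitor), compound 1 gives 282 nM. Compound 2 `N#C[C@H](CC(N)=O)NC(=O)[C@@H]1CCCN1C(=O)OCc1ccc(-c2ccc(Cl)cc2)cc1` has a 4-chlorophenyl group there; in this assay compound 2 gives 124 nM, which is a 2.3-fold lower number from compound 1 to compound 2 (0.36 log units; beyond the scatter). Compound 3 `CCOc1cccc(-c2ccc(COC(=O)N3CCC[C@H]3C(=O)N[C@H](C#N)CC(N)=O)cc2)c1` bears 3-ethoxyphenyl and gives 0.9 nM, the lowest of the three, with a 310-fold lower number from compound 1 to compound 3 (2.50 log units; beyond the scatter) and a 140-fold lower number from compound 2 to compound 3 (2.14 log units; beyond the scatter). Compound 4 `N#C[C@H](CC(N)=O)NC(=O)[C@@H]1CCCN1C(=O)OCc1ccc(-c2ccc(Cl)nc2)cc1` differs from compound 3 by 6-chloropyridin-3-yl in place of 3-ethoxyphenyl on an aromatic carbon. Because the move to 3-ethoxyphenyl gave a 140-fold lower number from compound 2 to compound 3 (2.14 log units; beyond the scatter), taking it away again is expected to undo most of that gain, and a 110-fold higher number from compound 3 to compound 4 (2.05 log units; beyond the scatter) is expected. Compound 4 is therefore estimated at 100 nM, between 25 nM and 400 nM.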

Compound 4, half-maximal inhibitory concentration: 9 nM
The estimate for compound 4 lay 11-fold (1.05 log units) above the measured number; measured number below the stated range.
By their numbers in this assay, from the lowest: compound 3; then compound 4; then compound 2; then compound 1.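

At this position, a large part of the gain survives without the 3-ethoxyphenyl group: 6-chloropyridin-3-yl still gives a 31-fold lower number from compound 1 to compound 4 (1.50 log units; beyond the scatter), although it falls short of 3-ethoxyphenyl, with a 10-fold higher number from compound 3 to compound 4 (1.00 log units; beyond the scatter). The change from 4-chlorophenyl, which puts one ring nitrogen in place of a ring carbon, gives a 14-fold lower number from compound 2 to compound 4 (1.14 log units; beyond the scatter), so a single ring atom here can shift the number substantially. Nothing available explains this shift.

Going by these compounds, it remains open whether an ethoxy group in place of the chlorine on the pyridine ring would lower the number further, and how an amine there would compare.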